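Piperidine attachment shift from compound 2 to compound 3

The source may hold more compounds than are shown below. What is called first, only, known or untested is meant among the compounds shown, and "the series" means these compounds.

In an ADME assay on MT2 cells (Homo sapiens) for cytotoxicity, read by XTT assay, with a stated time of 4 days (on this read-out higher numbers stand for lower toxicity in this test and lower numbers for higher toxicity in this test), compound 1 (`Cc1nc(C(NC(=O)C(=O)Nc2ccc(Cl)cc2)C2CCNCC2)sc1CO`) gives > 81000 nM as a limit of the assay. Compound 2 (`Cc1nc(C(NC(=O)C(=O)Nc2ccc(Cl)cc2)C2CCNCC2)sc1CCO`) likewise stands only at a limit with > 78500 nM as its entry. Compound 3 (`Cc1nc(C(NC(=O)C(=O)Nc2ccc(Cl)cc2)C2CCCNC2)sc1CCO`) differs from compound 2 by piperidin-3-yl in place of piperidin-4-yl on a saturated chain carbon bound to an amide-type nitrogen and an aromatic carbon in the form of piperidin-3-yl in place of piperidin-4-yl on a saturated chain carbon bound to an amide-type nitrogen and an aromatic carbon. Going by the values given here, the sole measured step (a step that the two limits leave unreadable from compound 1 to compound 2) changes another place and has no readable size. No step beyond the scatter is therefore expected in this assay (an at least 1.0-fold lower number from compound 2 to compound 3 (0.01 log units; that floor lies within the scatter)). For compound 3 the expected value is 75000 nM with an estimated range from 35000 nM to 100000 nM and a likely report as a limit.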

Compound 3, half-maximal cytotoxic concentration: > 78500 nM
Compound 3: no number, only a limit; the forecaster's own chance of this, stated with the estimate: 75%; middle value at least 1.0-fold (0.01 log units) from the limit.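

Compound 2 and compound 3 both stand only at a limit in this assay, so no step can be read between them. From the compounds shown here alone, the size of any difference between piperidin-3-yl and piperidin-4-yl in this assay remains open.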